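Compound 3 and the swap to a 3-cyanophenyl group

This account rests on a few compounds, and the source may have more. Where it says the series, first, only, none or still open, it means among the compounds named here.

Measured so far in an ADME assay on HUVEC cells (Homo sapiens) for inhibition, read by CCK-8 assay, with a stated time of 24 h, in the presence of a further agent that is not named here; on this read-out higher numbers stand for weaker inhibition and lower numbers for stronger inhibition
compound 1 `O=C1Nc2ccccc2/C1=C/c1ccc(-c2cn(-c3ccccc3F)nn2)cc1` gives 19300 nM
compound 2 `N#Cc1ccc(-n2cc(-c3ccc(C=C4C(=O)Nc5ccccc54)cc3)nn2)cc1` gives > 20000 nM (a limit of the assay)
compound 3 `O=C1Nc2ccc(F)cc2/C1=C/c1ccc(-c2cn(-c3ccccc3F)nn2)cc1` gives 14400 nM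
Not yet measured: compound 4 `N#Cc1cccc(-n2cc(-c3ccc(/C=C4\C(=O)Nc5ccc(F)cc54)cc3)nn2)c1`

Within the data shown here, compound 3 has the lowest of the two true numbers, though only one other compound has a true number and the gap to it lies within the scatter (a 1.3-fold lower number from compound 1 to compound 3 (0.13 log units; within the scatter)). The move to compound 4 puts 3-cyanophenyl in place of 2-fluorophenyl on an aromatic nitrogen. Among the measured compounds shown here, the single measured step, fluoro in place of hydrogen on an aromatic carbon, lies elsewhere in the molecule, so it offers no direct guide to this change. For compound 2, which also carries a cyanophenyl group on that aromatic nitrogen, the value (> 20000 nM) is a limit of the assay. That gives a slight lean towards a higher number in this assay but no expectation of a step beyond the scatter. The expected step is small (a 1.3-fold higher number from compound 3 to compound 4 (0.10 log units; within the scatter)). Compound 4 is expected at about 18000 nM (estimated range 8000 nM to 32000 nM).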

Compound 4, half-maximal inhibitory concentration: > 20000 nM
Compound 4: no number, only a limit; the forecaster's own chance of this, stated with the estimate: 40%; at least 1.1-fold (0.04 log units) between middle value and limit.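

In this assay, the change from 2-fluorophenyl to 3-cyanophenyl on the aromatic nitrogen gives the first step read directly at this position: an at least 1.3-fold higher number from compound 3 to compound 4 (0.14 log units; that floor lies within the scatter). Compound 4 gives > 20000 nM, which is a limit of the assay, so the step has a floor but no true size. How far the change really reaches cannot be told because the read-out ends at that limit: the limit of > 20000 nM in this assay, at which 2 of the 4 values shown sit.

The compounds shown leave open whether a different group on this aromatic nitrogen, such as an aminophenyl group, a carboxylic acid or a longer alkyl chain, would give a true number clearly apart from that of compound 3. They also leave open how 3-cyanophenyl would read on the core of compound 1, which lacks the fluoro group.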